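Shortening the sulfonyl side chain in the catechol vinyl sulfone series

This account rests on a few compounds, and the source may have more. Where it says the series, first, only, none or still open, it means among the compounds named here.

Compound 2 `O=S(=O)(/C=C/c1ccc(O)c(O)c1)CCC1CCCC1` gives 6800 nM in a functional assay, read by fluorescence and spectrophotometry, with a stated time of 1 h; a lower number here means that less compound is needed, a higher number that more compound is needed for the effect. For the measured compounds named here, on the two numbers so far compound 2 stands highest, its nearest neighbour being compound 1 `CCCCCCCCS(=O)(=O)/C=C/c1ccc(O)c(O)c1`, which in this assay gives 6400 nM; the step of a 1.1-fold higher number from compound 1 to compound 2 (0.03 log units; within the scatter) lies within the scatter, so the two compounds cannot be ordered. Compound 3 `O=S(=O)(/C=C/c1ccc(O)c(O)c1)CC1CC1` has not yet been measured in this assay. It differs from compound 2 by cyclopropyl in place of cyclopentylmethyl on a saturated chain carbon bound to a sulfonyl sulfur. Going by the values given here, the only measured step, a 1.1-fold higher number from compound 1 to compound 2 (0.03 log units; within the scatter), concerns a change two bonds along the chain from a sulfonyl sulfur and was within the scatter; it offers no direction for a change on the carbon bound to the sulfonyl sulfur, where the entering group is smaller than the leaving group. The expected step is a 1.5-fold higher number from compound 2 to compound 3 (0.17 log units; within the scatter), with no clear direction and a wide range. Compound 3 is estimated at 10000 nM, between 4000 nM and 30000 nM.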

Compound 3, half-maximal effective concentration: 10500 nM
Estimate against measurement, compound 3: 1.1-fold (0.02 log units) below; low and high end bracket the measured number.
By their numbers in this assay, from the lowest: compounds 1, 2 and 3 (each within the scatter of the next).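

In this assay the change on the saturated chain carbon bound to a sulfonyl sulfur, cyclopropyl in place of cyclopentylmethyl, gives a 1.5-fold higher number from compound 2 to compound 3 (0.19 log units; within the scatter) and stays inside the scatter, even with 3 heavy atoms entering and 6 leaving. Cyclopropyl in place of heptyl at the same place gives a 1.6-fold higher number from compound 1 to compound 3 (0.22 log units; within the scatter) and also stays inside the scatter, so the three side chains shown cannot be ordered, whether they carry a three-membered ring, a five-membered ring or no ring.

Going by these compounds, whether a side chain bearing an amine or a carboxylic acid would give a step beyond the scatter remains open. So does the outcome of a chain longer than heptyl, since all three groups shown are plain carbon.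

No supporting data accompany these steps to account for them.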